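A few compounds are considered here, and "the series" means these few. Any claim that something is new, unique, unknown or untested is made for them only; others in the source may bear on it.

Measured compounds:
- compound 1, `O=C(CN1CCN(c2ccccn2)CC1)Nc1cccnc1`: 86500 nM
- compound 2, `Cc1cccc(NC(=O)CCN2CCC(c3ccccn3)CC2)c1`: 6340 nM
- compound 3, `Cc1ccc(C2CCN(CC(=O)Nc3cccc(C)c3)CC2)cc1`: 3060 nM

In a functional assay on cells for antagonist activity at D(4) dopamine receptor (Homo sapiens), read by TR-FRET and cAMP accumulation, with a stated time of 30 min (a lower number here means a stronger inhibitor, a higher number a weaker inhibitor), compound 1 gives 86500 nM, the highest of the three numbers. Its nearest neighbour is compound 2, whose value in this assay is 6340 nM, and the gap between them lies beyond the scatter; the furthest is compound 3 at 3060 nM, again a gap beyond the scatter. Compound 1 is thus the weakest inhibitor among the measured compounds.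

Compound 4, `Cc1cccc(NC(=O)CN2CCN(c3ccccn3)CC2)c1`, has not yet been measured in this assay. It differs from compound 1 in one place: 3-methylphenyl in place of pyridin-3-yl on an amide-type nitrogen. The 3-methylphenyl group that enters on the amide-type nitrogen is also the group carried on the amide of compound 2 and of compound 3, which both sit far below compound 1.

A step towards a lower number, beyond the scatter, is therefore expected from compound 1 to compound 4, estimated at an 11-fold lower number from compound 1 to compound 4 (1.03 log units; beyond the scatter), because compound 2 with the same amide group gives 6340 nM. Compound 4 is estimated to give 8000 nM, with a range from 2000 nM to 30000 nM.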

Compound 4, half-maximal inhibitory concentration: 82.7 nM
Compound 4: the middle estimate sits 97-fold (1.99 log units) above what was measured, outside the stated range (below it).
By their numbers in this assay, from the lowest: compound 4; then compound 3; then compound 2; then compound 1.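

In this assay, going by these compounds alone, putting 3-methylphenyl in place of pyridin-3-yl on the amide-type nitrogen gives a 1000-fold lower number from compound 1 to compound 4 (3.02 log units; beyond the scatter), the first direct reading of this position, as no earlier pair of compounds differed in one place. With the rest of the core of compound 1 unchanged, this single exchange is enough to produce a large step, so the group on the amide-type nitrogen has a strong bearing on the number in this assay. No measurement at hand accounts for the size of this step.

The step combines the loss of the ring nitrogen with the gain of the methyl, and compound 1 and compound 4 cannot separate the two. A plain phenyl on the amide-type nitrogen would address this, while 3-chlorophenyl or 3-methoxyphenyl would show whether the methyl itself can be exchanged.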